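The source may report more compounds than this note shows. Statements on the series, on what has been measured and on what is new or still open speak of the compounds shown alone.

Measured compounds:
- compound 1 `Oc1ccc(N2CCN(CC(O)COc3cccc4ccccc34)CC2)c(O)c1`: 11600 nM
- compound 2 `Oc1ccccc1N1CCN(CC(O)COc2ccc(O)c3ccccc23)CC1`: > 50000 nM

Both compounds were tested in a functional assay on DU-145 cells (Homo sapiens) for antiproliferative activity, read by MTT assay, with a stated time of 48 h; a lower number here means a stronger inhibitor, a higher number a weaker inhibitor. Compound 1 gives 11600 nM in this assay. For compound 2 the result is only a limit, > 50000 nM, so no number is known for it; compound 2 therefore stands at the weak end of what is shown, on (the limit of > 50000 nM in this assay, at which 1 of the 2 values shown sits), while compound 1 lies well inside the measurable range.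

The next compound, compound 3 `Oc1ccccc1N1CCN(CC(O)COc2cccc3ccccc23)CC1`, differs from compound 2 in one place: hydrogen in place of hydroxy on an aromatic carbon. Going by the values given here, no measured pair shows this exact step, so its size must be judged indirectly. Compound 3 shares with compound 1 the naphthyl ether that carries no hydroxy, and compound 1 gives a number rather than a limit. On that basis compound 3 is expected to come back into the measurable range, with a step of an at least 2.5-fold lower number from compound 2 to compound 3 (0.39 log units; beyond the scatter) toward stronger inhibition. Compound 3 is estimated at 20000 nM in this assay, between 6000 nM and 60000 nM.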

Compound 3, half-maximal inhibitory concentration: 18000 nM
The estimate for compound 3 lay 1.1-fold (0.05 log units) above the measured number, and the stated range covers the measured number.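

In this assay, hydrogen in place of hydroxy on the aromatic carbon para to a large group, on the ring that is part of a fused system of two rings, gives an at least 2.7-fold lower number from compound 2 to compound 3 (0.44 log units; beyond the scatter), so this pair shows that a hydroxy at this place goes with weaker inhibition. The size of that step has only a lower bound, since compound 2 is given only as a limit and not as a number: the limit of > 50000 nM in this assay, at which 1 of the 3 values shown sits. The same exchange made at another place in the core gives a 1.6-fold higher number from compound 1 to compound 3 (0.19 log units; within the scatter), which lies within the scatter, so in these two pairs the hydroxy matters at the place on the fused system and cannot be told apart from no change at the other place.

As far as these compounds go, what remains open is whether the weaker inhibition belongs to hydroxy itself or would follow any group at this place, as a methoxy, an amine or a chlorine there could tell. Also open, from the compounds shown here alone, is how far compound 2 really lies from compound 3, and whether a hydroxy at other carbons of the fused system behaves as this one does.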